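The compounds below may be only part of what the source reports. "The series", "measured", "known", "first", "only" and "open" are said of these compounds alone.

The shared core of compound 2 `CCCCNC(=O)c1ccc2c(ccn2-c2ncc3c(n2)N(C2CCCC2)[C@H](CC)C(=O)N3C)c1` carries an indole linked through its nitrogen and a butylcarbamoyl on the bicyclic ring; in a functional assay on MCF7 cells (Homo sapiens) for antiproliferative activity, read by CCK-8 assay, with a stated time of 72 h (on this read-out lower numbers stand for stronger inhibition of growth and higher numbers for weaker inhibition of growth), compound 2 gives 634 nM. Compound 1 `CCCNS(=O)(=O)c1ccc(Nc2ncc3c(n2)N(C2CCCC2)[C@H](CC)C(=O)N3C)cc1` reaches 344 nM in this assay, a value that sits within the scatter of compound 2, so the two stand together. Compound 3 `CCC1C(=O)N(C)c2cnc(-n3ccc4cc(C(=O)NC5CCCC5)ccc43)nc2N1c1ccn(C)n1` is reported only as "not active" (no number reported) in this assay, without a number. Compound 4 `CC[C@@H]1C(=O)N(C)c2cnc(-n3ccc4ccccc43)nc2N1C1CCCC1` differs from compound 2 in one place: hydrogen in place of butylcarbamoyl on an aromatic carbon. For the measured compounds named here, no measured pair shows this step. Because compound 3, the other amide-bearing analogue, reads "not active" (no number reported), no anchor exists for the loss of the amide; compound 4 is therefore expected to weaken somewhat, with a 2.4-fold higher number from compound 2 to compound 4 (0.37 log units; beyond the scatter) as the estimated step, to 1500 nM ranging from 400 nM to 6000 nM.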

Compound 4, concentration for 50% growth inhibition: 17200 nM
The estimate for compound 4 lay 11-fold (1.06 log units) below the measured number, outside the stated range (above it).
By their numbers in this assay, from the lowest: compounds 1 and 2 (each within the scatter of the next); then compound 4.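

In this assay, for the compounds shown here, the replacement of butylcarbamoyl by hydrogen gives a 27-fold higher number from compound 2 to compound 4 (1.43 log units; beyond the scatter) and so provides the first measured step at this aromatic carbon. The growth inhibition seen with compound 2 therefore depends strongly on having butylcarbamoyl rather than hydrogen at this place. No measurement offered here bears on what lies behind this large loss. The compounds shown leave open whether the amide itself is needed or whether another group would serve as well. A carboxylic acid, an amine or a longer chain on this carbon could separate those two readings.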